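Compound 3: Isopropyl in Place of Benzyl

This account rests on a few compounds, and the source may have more. Where it says the series, first, only, none or still open, it means among the compounds named here.

Measured in an assay on isolated protein (plant) for inhibition of Pepsin A (Sus scrofa); on this read-out higher numbers stand for weaker inhibition and lower numbers for stronger inhibition:
compound 1 `CCCCCCC(O)[C@H](CC(C)C)NC(=O)[C@@H](NC(=O)[C@@H](NC(=O)CC(C)C)C(C)C)C(C)C`: 920 nM
compound 2 `CCCCCCC(O)[C@H](CC(C)C)NC(=O)[C@@H](NC(=O)[C@@H](NC(=O)OCc1ccccc1)C(C)C)C(C)C`: 690 nM

Compound 2 and compound 1 lie within the scatter of each other, as a 1.3-fold lower number from compound 1 to compound 2 (0.12 log units; within the scatter) shows. Compound 3 `CCCCCCC(O)[C@H](CC(C)C)NC(=O)[C@@H](NC(=O)[C@@H](NC(=O)OC(C)C)C(C)C)C(C)C` differs from compound 2 by isopropyl in place of benzyl on an oxygen next to a carbonyl group. Among the compounds with values here, the only step that touches this part of the structure is a 1.3-fold lower number from compound 1 to compound 2 (0.12 log units; within the scatter), and it stayed within the scatter, so no step beyond the scatter is expected here either: the estimated step is a 1.2-fold higher number from compound 2 to compound 3 (0.06 log units; within the scatter). Compound 3 is therefore expected to give about 800 nM in this assay, within a range from 350 nM to 1800 nM.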

Compound 3, half-maximal inhibitory concentration: 1200 nM
Beside the measured number, compound 3's estimate is 1.5-fold (0.18 log units) below it; the range from low to high includes it.
By their numbers in this assay, from the lowest: compounds 2, 1 and 3 (each within the scatter of the next).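

In this assay, the six-membered aromatic ring of benzyl turns out not to matter at this position: isopropyl in place of benzyl on an oxygen next to a carbonyl group gives a 1.7-fold higher number from compound 2 to compound 3 (0.24 log units; within the scatter). Exchanging the isobutyl end group for an isopropoxy one likewise gives a 1.3-fold higher number from compound 1 to compound 3 (0.12 log units; within the scatter), so all three end groups lie within the scatter of one another, with or without a ring. No available evidence explains this insensitivity.
Still open, from the compounds shown here alone, is whether an amine, a carboxylic acid or a longer chain at this position would produce a step beyond the scatter.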